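This account rests on a few compounds, and the source may have more. Where it says the series, first, only, none or still open, it means among the compounds named here.

Working notes on the series. Compound 3 `Nc1scc(CN2CCN(c3ccc(OC(F)(F)F)cc3)CC2)c1C(=O)c1ccc(Cl)cc1` carries a 4-(trifluoromethoxy)phenyl on an amine nitrogen in a ring. In an assay on CHO cells for displacement of a labelled ligand from adenosine receptor A1 (Homo sapiens), read by scintillation counting, with a stated time of 120 min, tested at 10 uM (a higher number here means more inhibition at the concentration tested (going by the name of the read-out), a lower number less inhibition), compound 3 gives 0%. Compound 1 `Nc1scc(CN2CCN(c3cccc(C(F)(F)F)c3)CC2)c1C(=O)c1ccc(Cl)cc1` gives 0% in this assay, and compound 2 `Nc1scc(CN2CCN(c3ccccc3C(F)(F)F)CC2)c1C(=O)c1ccc(Cl)cc1` gives 0%. Compound 3 thus stands level with compounds 1 and 2 at the digits printed. Each single change among the three measured compounds left the read-out flat: no change at the digits printed from compound 1 to compound 2 (within the scatter), no change at the digits printed from compound 1 to compound 3 (within the scatter), and no change at the digits printed from compound 2 to compound 3 (within the scatter).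

Compound 4 `Nc1scc(CN2CCN(c3ccccc3F)CC2)c1C(=O)c1ccc(Cl)cc1` differs from compound 3 as follows: 2-fluorophenyl in place of 4-(trifluoromethoxy)phenyl on an amine nitrogen in a ring. All three measured steps exchange the aryl group on the amine nitrogen in a ring, and every one of them stayed within the scatter; the present change is of the same kind. The step is therefore expected to be none beyond the scatter, no change at the digits printed from compound 3 to compound 4 (within the scatter). Compound 4 is expected to give 0% in this assay, with a range from -8% to 12%.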

Compound 4, a percentage reported as inhibition, at one concentration (the size of the read-out at that concentration, not a potency): 4%
Compound 4: the middle estimate sits 4 percentage points below what was measured; measured number inside the range.
By their numbers in this assay, from the lowest: compounds 1, 2, 3 and 4 (each within the scatter of the next).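

On the amine nitrogen in a ring, 2-fluorophenyl is the only aryl group shown that carries neither trifluoromethyl nor trifluoromethoxy, and in this assay its exchange for 4-(trifluoromethoxy)phenyl gives a number 4 percentage points higher from compound 3 to compound 4 (within the scatter). Fluoro in place of trifluoromethyl on an aromatic carbon gives a number 4 percentage points higher from compound 2 to compound 4 (within the scatter), and 2-fluorophenyl in place of 3-(trifluoromethyl)phenyl gives a number 4 percentage points higher from compound 1 to compound 4 (within the scatter), so a group of 7 heavy atoms at this position reads the same, within the scatter, as the larger aryl groups. No measured information bears on this result.

From the compounds shown here alone, whether a group other than a substituted phenyl on this nitrogen, such as a benzyl group or a simple alkyl chain, would move the read-out remains open. The four compounds also give no ranking of their aryl groups in this assay, and they do not show whether an amine or a carboxylic acid on the phenyl ring would change this flat picture.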